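This account rests on a few compounds, and the source may have more. Where it says the series, first, only, none or still open, it means among the compounds named here.

Four compounds are considered here, built on two closely related cores. Compound 1 `O=C(Nc1ccc(Oc2ccnc3[nH]ccc23)c(F)c1)c1nn(-c2ccc(Br)cc2)ccc1=O` carries a 4-bromophenyl group, while compound 2 `O=C(Nc1ccc(Oc2ccnc3[nH]ccc23)c(F)c1)c1nn(-c2ccccc2)ccc1=O` carries a plain phenyl group in its place. Both were tested in a functional assay on HepG2 cells (Homo sapiens) for cytotoxicity, read by MTT assay, with a stated time of 72 h; on this read-out lower numbers stand for stronger inhibition and higher numbers for weaker inhibition. In this assay compound 1 gives 68000 nM, and compound 2 gives 24900 nM. The step of a 2.7-fold lower number from compound 1 to compound 2 (0.44 log units; beyond the scatter) comes from the change (hydrogen in place of bromo on an aromatic carbon).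

Compound 3 `Cn1ccc2c(Oc3ccc(NC(=O)c4nn(-c5ccc(Br)cc5)ccc4=O)cc3)ccnc21` rests on a different core; the difference between the core of compound 3 and the core of compound 1 is not broken down here. In this assay compound 3 gives 39200 nM, a number that lies within the usual scatter of the values of both compound 1 and compound 2, so no order among these three compounds can be read from it.

Compound 4 `Cn1ccc2c(Oc3ccc(NC(=O)c4nn(-c5ccccc5)ccc4=O)cc3)ccnc21` has not yet been measured. Among the compounds with values here, it differs from compound 3 by hydrogen in place of bromo on an aromatic carbon, the same change as the one leading from compound 1 to compound 2, made at the same place on the ring.

Within the data shown here, the expected step is a 2.5-fold lower number from compound 3 to compound 4 (0.39 log units; beyond the scatter), a figure that rests on the single measured example a 2.7-fold lower number from compound 1 to compound 2 (0.44 log units; beyond the scatter) and on the value of compound 3, 39200 nM; with only one example behind it, the range is kept wide. Compound 4 is therefore estimated at 16000 nM, expected to fall between 7000 nM and 40000 nM.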

Compound 4, half-maximal inhibitory concentration: 56200 nM
The estimate for compound 4 lay 3.5-fold (0.55 log units) below the measured number; measured number above the stated range.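

In this assay, swapping the 4-bromophenyl group for phenyl on the second core gives a 1.4-fold higher number from compound 3 to compound 4 (0.16 log units; within the scatter), so these two compounds cannot be told apart by this measurement. The same swap did not behave alike on the two cores: the same change on two cores in this assay, a 2.7-fold lower number (0.44 log units; beyond the scatter) from compound 1 to compound 2 and a 1.4-fold higher number (0.16 log units; within the scatter) from compound 3 to compound 4, 3.9-fold (0.59 log units) apart, beyond the scatter of two such steps. Within the data shown here, this shows that, in this small set, a step measured on one core was a poor guide to the same change on the other, so the bromo-to-hydrogen swap cannot be treated as a fixed increment here; it does not show why the two steps differ, and with only one pair on each core, it cannot tell which step is more typical or what a third core would do.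

The two cores differ in more than one place, and no compound shown separates those differences, so it remains open which of them goes with the change in the step. From the compounds shown here alone, it is also open whether a chloro, methoxy or amine group, placed para to the same large group, would give matching steps on both cores or would diverge as the bromo-to-hydrogen change does.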